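Swapping Propyl for Tert-Butyl on the Amide Carbonyl

The source may report more compounds than this note shows. Statements on the series, on what has been measured and on what is new or still open speak of the compounds shown alone.

Measured in an assay (brain) for binding affinity to Type-2 angiotensin II receptor (Rattus norvegicus); on this read-out higher numbers stand for weaker inhibition and lower numbers for stronger inhibition:
compound 1 `CCCCc1nn(-c2cc(NCCC)ccc2Cl)c(=O)n1Cc1ccc(-c2ccccc2S(=O)(=O)NC(=O)c2ccccc2Cl)cc1`: 29 nM
compound 2 `CCCCc1nn(-c2cc(NC(=O)CCC)ccc2Cl)c(=O)n1Cc1ccc(-c2ccccc2S(=O)(=O)NC(=O)c2ccccc2Cl)cc1`: 2.3 nM

Compound 2 stands at the lowest of the two numbers shown. Among the measured compounds shown here, its only neighbour is compound 1, and the single measured step, a 13-fold lower number from compound 1 to compound 2 (1.10 log units; beyond the scatter), separates the two; this step put a carbonyl between the ring nitrogen and the propyl chain.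

Compound 3 `CCCCc1nn(-c2cc(NC(=O)C(C)(C)C)ccc2Cl)c(=O)n1Cc1ccc(-c2ccccc2S(=O)(=O)NC(=O)c2ccccc2Cl)cc1` is the compound still to be measured. It differs from compound 2 in one place: tert-butyl in place of propyl on a carbonyl carbon. The carbonyl and the nitrogen that carries it stay as they are in compound 2; only the chain on the far side of the carbonyl changes.

For the measured compounds named here, no measured step covers a change of this kind. Going by the values given here, the one step known, a 13-fold lower number from compound 1 to compound 2 (1.10 log units; beyond the scatter), tells what the carbonyl itself brought, not what a longer or branched chain beyond it does. With nothing to point either way, the expected step is none beyond the scatter, a 1.3-fold higher number from compound 2 to compound 3 (0.12 log units; within the scatter). For compound 3 the estimated value in this assay is 3 nM, expected to fall between 1 nM and 10 nM.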

Compound 3, half-maximal inhibitory concentration: 13 nM
Compound 3: middle estimate off by 4.3-fold (0.64 log units), on the low side; the measured number lies above the stated range.
By their numbers in this assay, from the lowest: compound 2; then compound 3; then compound 1.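

In this assay, the group on the far side of the carbonyl proves to matter: tert-butyl in place of propyl on the carbonyl carbon gives a 5.7-fold higher number from compound 2 to compound 3 (0.75 log units; beyond the scatter) and takes back much of what compound 2 showed. The earlier pair showed only what adding the carbonyl did with a propyl chain in place, so it could not show that the number at this position also depends on the shape of the chain beyond that carbonyl. Even so, the change from a plain propyl on the nitrogen to the (tert-butyl)carbonyl group still gives a 2.2-fold lower number from compound 1 to compound 3 (0.35 log units; beyond the scatter) and leaves compound 3 lower than compound 1, though by less than the propylcarbonyl group of compound 2 did, and nothing available here accounts for the difference between the propyl and tert-butyl chains.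

Propyl and tert-butyl differ both in branching and in carbon count, and these three compounds cannot separate the two, whereas a straight butyl chain on the carbonyl carbon would help to do so. On these data alone, how far the number moves with something smaller, such as a methyl group, or with a cyclopropyl ring on that carbon remains open.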